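This account rests on a few compounds, and the source may have more. Where it says the series, first, only, none or still open, it means among the compounds named here.

Measured compounds in a functional assay on HEK293 cells for negative allosteric modulation of metabotropic glutamate receptor 5 (Rattus norvegicus), read by FLIPR and calcium flux, with a stated time of 170 s; a lower number here means a stronger inhibitor, a higher number a weaker inhibitor:
- compound 1, `N#Cc1ccc(CC(=O)c2cc3n(n2)CCCC3)nc1`: 53 nM
- compound 2, `N#Cc1ccc(CC(=O)c2nn3c(c2Cl)CCCC3)nc1`: 108 nM

Going by the values given here, compound 2 stands at the highest number of the two measured so far; its nearest neighbour is compound 1, and the step of a 2.0-fold higher number from compound 1 to compound 2 (0.31 log units; beyond the scatter) is beyond the scatter, though only modest in size. The shared core of compound 1 and compound 2 is otherwise unchanged between them.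

Compound 3, `N#Cc1ccc(CC(=O)c2nn3c(c2C(F)(F)F)CCCC3)nc1`, is not yet measured. Relative to compound 2 the change is trifluoromethyl in place of chloro on an aromatic carbon.

Among the compounds with values here, the only measured step that bears on this position is a 2.0-fold higher number from compound 1 to compound 2 (0.31 log units; beyond the scatter), in which a hydrogen at this aromatic carbon became a chloro and the number rose somewhat. Within the data shown here, compound 3 carries a trifluoromethyl at the same carbon, so the comparison is between two substituted analogues and no direct precedent for this exchange exists. Working from the single step at this position, a small shift toward a higher number, likely within the scatter, is expected for compound 3, giving an expected step of a 1.4-fold higher number from compound 2 to compound 3 (0.14 log units; within the scatter).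

The estimate for compound 3 in this assay is 150 nM, expected to fall between 60 nM and 400 nM.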

Compound 3, half-maximal inhibitory concentration: 7180 nM
The estimate for compound 3 lay 48-fold (1.68 log units) below the measured number; measured number above the stated range.
By their numbers in this assay, from the lowest: compound 1; then compound 2; then compound 3.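

In this assay this aromatic carbon turns out to be far more sensitive to the choice of substituent than the first exchange indicated: the hydrogen to chloro change gave only a 2.0-fold higher number from compound 1 to compound 2 (0.31 log units; beyond the scatter) and a modest rise, whereas trifluoromethyl in place of chloro gives a 66-fold higher number from compound 2 to compound 3 (1.82 log units; beyond the scatter) and moves the series into a much weaker range. Against the hydrogen compound, trifluoromethyl gives a 140-fold higher number from compound 1 to compound 3 (2.13 log units; beyond the scatter) as a large step, so a substituent at this carbon is not uniformly a small penalty, and the two groups tried here differ sharply in their effect on inhibition. Nothing available accounts for this jump, and no measurement on these compounds speaks to its origin.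

As far as these compounds go, with only hydrogen, chloro and trifluoromethyl at this carbon, it remains open whether the number climbs gradually or abruptly as the group grows, which a fluoro or a methyl group there would help to settle. Also open is how a methoxy group or an amine at this carbon would behave, since all three compounds shown keep the same nitrile-bearing side of the molecule and the same carbonyl link.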